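A Methoxy-to-(2-Hydroxyethyl)amino Swap on a Shared Core

A few compounds are considered here, and "the series" means these few. Any claim that something is new, unique, unknown or untested is made for them only; others in the source may bear on it.

Of the compounds shown here, three on a shared core have been measured in an assay on microsomes for inhibition of acyl-CoA:cholesterol acyltransferase (Oryctolagus cuniculus); a higher number here means a weaker inhibitor, a lower number a stronger inhibitor. Compound 1 `Cc1ccccc1C1(CNC(=O)Nc2c(C(C)C)cccc2C(C)C)CCCC1` gives 17 nM. Compound 2 `COc1ccc(C2(CNC(=O)Nc3c(C(C)C)cccc3C(C)C)CCCC2)cc1` gives 31 nM, and compound 3 `CC(C)c1cccc(C(C)C)c1NC(=O)NCC1(c2cccc(OCc3ccccc3)c2)CCCC1` gives 30 nM. Compound 2 carries the highest of the three numbers, yet its nearest neighbour is compound 3 and its furthest is compound 1, and both of those gaps lie within the scatter, so no ordering among the three can be claimed. Among the measured compounds shown here, the only step between two compounds that differ in one place is a 1.8-fold higher number from compound 1 to compound 2 (0.26 log units; within the scatter), where 4-methoxyphenyl replaces 2-methylphenyl on a saturated ring carbon.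

The unmeasured compound 4 `CC(C)c1cccc(C(C)C)c1NC(=O)NCC1(c2ccc(NCCO)cc2)CCCC1` differs from compound 2 as follows: (2-hydroxyethyl)amino in place of methoxy on an aromatic carbon. For the measured compounds named here, no measured step touches the aromatic carbon para to the large group in this way; the one step available, from compound 1 to compound 2, changed a different part of the aryl ring and stayed within the scatter. With nothing beyond that to go on, a step in this assay of no more than the scatter is expected for compound 4, in either direction, as a 1.1-fold higher number from compound 2 to compound 4 (0.05 log units; within the scatter). Compound 4 is therefore estimated at 35 nM, with a range from 12 nM to 110 nM.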

Compound 4, half-maximal inhibitory concentration: 25 nM
Beside the measured number, compound 4's estimate is 1.4-fold (0.15 log units) above it, within the range that was stated.
By their numbers in this assay, from the lowest: compounds 1, 4, 3 and 2 (each within the scatter of the next).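

In this assay, putting (2-hydroxyethyl)amino in place of methoxy on an aromatic carbon para to a large group gives a 1.2-fold lower number from compound 2 to compound 4 (0.09 log units; within the scatter), so a group with more heavy atoms and with hydrogen-bond donors, which methoxy lacks, leaves the number within the scatter at this position. Measured against the 2-methylphenyl group of compound 1, the new 4-((2-hydroxyethyl)amino)phenyl group gives a 1.5-fold higher number from compound 1 to compound 4 (0.17 log units; within the scatter), and this step also stays within the scatter, as does the earlier step to 4-methoxyphenyl (a 1.8-fold higher number from compound 1 to compound 2 (0.26 log units; within the scatter)). There is no further evidence that bears on this result.

The compounds shown leave open whether a primary amine, a carboxylic acid or a longer chain on the same aromatic carbon would also stay within the scatter of compound 2, or whether some group there would give a step beyond it. They also leave open whether the hydroxyl of the (2-hydroxyethyl)amino group matters to the number, a question that an ethylamino group at the same place would address.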